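From 1,3-thiazol-5-yl to pyrimidin-5-yl

A few compounds are considered here, and "the series" means these few. Any claim that something is new, unique, unknown or untested is made for them only; others in the source may bear on it.

In an ADME assay on L6 cells (Rattus norvegicus) for cytotoxicity, read by resazurin assay, with a stated time of 72 h (on this read-out higher numbers stand for weaker inhibition and lower numbers for stronger inhibition), compound 1 `OC(c1ccc(Cl)cc1)(c1cccnc1)c1cccc(Br)c1` gives 54100 nM. Compound 2 `OC(c1ccc(Cl)cc1)(c1cccnc1)c1cncs1` gives > 100000 nM, which is a limit of the assay and not a number. Among the compounds with values here, the only measured step is an at least 1.8-fold higher number from compound 1 to compound 2 (0.26 log units; that floor lies within the scatter), so it shows no change beyond the scatter. Compound 3 `OC(c1ccc(Cl)cc1)(c1cccnc1)c1cncnc1` carries pyrimidin-5-yl in place of 1,3-thiazol-5-yl on a saturated chain carbon bound to two aromatic carbons and an oxygen on a saturated carbon. No step beyond the scatter is expected, and the estimated step is a number no higher from compound 2 to compound 3 (the limit leaves the size open). Compound 3 is expected at about 100000 nM, within an estimated range of 50000 nM to 200000 nM.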

Compound 3, half-maximal inhibitory concentration: > 100000 nM
Compound 3 was reported as a limit (the forecaster's own chance of this, stated with the estimate: 65%); the middle value lies on the limit itself.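

In this assay compound 3 gives > 100000 nM, a limit of the assay and not a number, so a six-membered aromatic ring with 2 hetero atoms at this place ends where the five-membered ring of compound 2 ended: the limit of > 100000 nM in this assay, at which 2 of the 3 values shown sit. With two limits, the step between these two compounds cannot be read. Going from 3-bromophenyl to pyrimidin-5-yl gives an at least 1.8-fold higher number from compound 1 to compound 3 (0.26 log units; that floor lies within the scatter), so this change, too, shows nothing beyond the scatter.

Going by these compounds, how far past the limit compound 2 and compound 3 lie stays open. So does how an amine or a carboxylic acid at this place would read.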